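A new group on compound 3

The source may hold more compounds than are shown below. What is called first, only, known or untested is meant among the compounds shown, and "the series" means these compounds.

Measured in an ADME assay on microsomes from liver (Mus musculus) for pharmacokinetics, read by LC-MS, using NADPH, with stated times of 5 min, 15 min and 30 min, tested at 10 uM; a lower number here means slower removal, a higher number faster removal of the compound:
- Compound 1 `C[C@@H](c1ccc(NC(=O)N2CC(c3cccnc3)C2)cc1)N1Cc2ccccc2C1=O`: 123 mL.min-1.g-1
- Compound 2 `C[C@H](NC(=O)c1cccc(F)c1)c1ccc(NC(=O)N2CC(c3cccnc3)C2)cc1`: 60.9 mL.min-1.g-1
- Compound 3 `C[C@@H](c1ccc(NC(=O)N2CC(c3ccc(N)nc3)C2)cc1)N1Cc2ccccc2C1=O`: < 25 mL.min-1.g-1 (a limit of the assay, not a number)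

Compound 3 stands at the limit of < 25 mL.min-1.g-1 in this assay, at which 1 of the 3 values shown sits. Compound 4 `C[C@H](NC(=O)c1ncccn1)c1ccc(NC(=O)N2CC(c3ccc(N)nc3)C2)cc1` keeps the amino group of compound 3 and differs from it by a group of 9 heavy atoms (5 carbon, 3 nitrogen, 1 oxygen; one six-membered aromatic ring with 2 hetero atoms) in place of a group of 10 heavy atoms (8 carbon, 1 nitrogen, 1 oxygen; one five-membered non-aromatic ring with 1 hetero atom, one six-membered aromatic ring of carbon only), on a saturated chain carbon bound to an aromatic carbon and a saturated chain carbon. The change falls on a saturated chain carbon bound to an aromatic carbon and a saturated chain carbon.

Among the compounds with values here, two measured steps bear on this. The first is a 2.0-fold lower number from compound 1 to compound 2 (0.31 log units; beyond the scatter), which replaced the same leaving group at the same place, although with a different entering group than the ((pyrimidin-2-yl)carbonyl)amino of compound 4. The second is an at least 4.9-fold lower number from compound 1 to compound 3 (0.69 log units; beyond the scatter), made by amino in place of hydrogen on an aromatic carbon, and compound 4 carries that amino group too. Within the data shown here, neither step points to a higher number, and the one exchange at this place went modestly lower. On these data alone, no step beyond the scatter is therefore expected in this assay, and the direction remains open. The expected change is a step that the limit leaves unreadable from compound 3 to compound 4. In this assay compound 4 is estimated at 20 mL.min-1.g-1, with an expected range from 10 mL.min-1.g-1 to 38 mL.min-1.g-1.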

Compound 4, intrinsic clearance in microsomes: < 25 mL.min-1.g-1
Compound 4: only a limit was reported (the forecaster's own chance of this, stated with the estimate: 70%); the middle value does not contradict the limit.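

In this assay, compound 3 and compound 4 both sit at a limit of the assay, so no step between them can be read: the limit of < 25 mL.min-1.g-1 in this assay, at which 2 of the 4 values shown sit.

The compounds shown leave open whether ((pyrimidin-2-yl)carbonyl)amino in compound 4, in place of the group carried by compound 3, changes the read-out in this assay at all, and in which direction.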